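From Fluoro to Methoxy on the Phenyl Group

The source may hold more compounds than are shown below. What is called first, only, known or untested is meant among the compounds shown, and "the series" means these compounds.

Of the compounds shown here, three sharing one core have been measured in a functional assay on A549 cells (Homo sapiens) for inhibition, read by MTT assay, with a stated time of 72 h; on this read-out higher numbers stand for weaker inhibition and lower numbers for stronger inhibition. There, compound 1 `CC(C)(C)n1cc2c(n1)C(=O)CC1(CCN(C(=O)c3cc(-c4ccccc4)nc4ccccc34)CC1)O2` gives 1940 nM, compound 2 `CC(C)(C)n1cc2c(n1)C(=O)CC1(CCN(C(=O)c3cc(-c4ccccc4Cl)nc4ccccc34)CC1)O2` gives 2180 nM and compound 3 `CC(C)(C)n1cc2c(n1)C(=O)CC1(CCN(C(=O)c3cc(-c4ccc(F)cc4)nc4ccccc34)CC1)O2` gives 5770 nM. Compound 3 thus has the highest number of the three and the weakest inhibition. The next compound, compound 4 `COc1ccc(-c2cc(C(=O)N3CCC4(CC3)CC(=O)c3nn(C(C)(C)C)cc3O4)c3ccccc3n2)cc1`, has methoxy in place of fluoro on an aromatic carbon, para to a large group, turning 4-fluorophenyl into 4-methoxyphenyl: methoxy in place of fluoro on an aromatic carbon.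

The closest evidence is a 3.0-fold higher number from compound 1 to compound 3 (0.47 log units; beyond the scatter), a modest step in which fluoro replaced hydrogen on that same carbon. Also modest is a 2.6-fold higher number from compound 2 to compound 3 (0.42 log units; beyond the scatter), whereas a 1.1-fold higher number from compound 1 to compound 2 (0.05 log units; within the scatter) stays within the scatter. No measured compound carries methoxy, so neither the size nor the direction of the change is shown directly. With only these steps to go on, the number is expected to move slightly back toward those of the other two compounds, without leaving the scatter, an estimated 1.4-fold lower number from compound 3 to compound 4 (0.16 log units; within the scatter). For compound 4 the expected value in this assay is 4000 nM, with an estimated range from 1800 nM to 9000 nM.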

Compound 4, half-maximal inhibitory concentration: 3740 nM
The estimate for compound 4 lay 1.1-fold (0.03 log units) above the measured number, and the stated range covers the measured number.
By their numbers in this assay, from the lowest: compounds 1, 2, 4 and 3 (each within the scatter of the next, the first and the last beyond it).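

In this assay, methoxy in place of fluoro on this aromatic carbon, para to a large group, gives a 1.5-fold lower number from compound 3 to compound 4 (0.19 log units; within the scatter), so the two groups cannot be told apart on this read-out. Compound 4 also stays within the scatter of both other compounds, with a 1.9-fold higher number from compound 1 to compound 4 (0.29 log units; within the scatter) and a 1.7-fold higher number from compound 2 to compound 4 (0.23 log units; within the scatter), whereas compound 3 lies beyond the scatter of each; replacing hydrogen on this carbon therefore does not always give a step beyond the scatter, as fluoro did with a 3.0-fold higher number from compound 1 to compound 3 (0.47 log units; beyond the scatter) and methoxy did not. No measurement is available that would account for this difference between the two groups.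

The four compounds leave open how an amine, a carboxylic acid or a longer chain such as ethoxy on this same carbon would compare with fluoro and methoxy. They also leave open whether 4-methoxyphenyl would read the same way if the shared core were changed, and whether the pattern seen here would hold in any test other than this assay.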